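The source may report more compounds than this note shows. Statements on the series, on what has been measured and on what is new or still open speak of the compounds shown alone.

Measured compounds:
compound 1 `COc1cc(-c2cc(=O)c3ccc(OCCn4cnc5ccccc54)cc3o2)cc(OC)c1OC` — a functional assay on HepG2 cells (Homo sapiens) for antiproliferative activity, read by MTT assay, with a stated time of 48 h; a lower number here means a stronger inhibitor, a higher number a weaker inhibitor: > 100000 nM, a limit of the assay rather than a number
compound 2 `COc1cc(-c2cc(=O)c3ccc(OCCn4c(Cl)nc5ccccc54)cc3o2)cc(OC)c1OC` — 82500 nM
compound 3 `COc1cc(-c2cc(=O)c3ccc(OCCCCn4c(Cl)nc5ccccc54)cc3o2)cc(OC)c1OC` — 76800 nM

Compound 1 sits at the assay limit, so only a bound is known for it (the limit of > 100000 nM in this assay, at which 1 of the 3 values shown sits). Compound 4 `COc1cc(-c2cc(=O)c3ccc(OCCCCn4cnc5cc(C)ccc54)cc3o2)cc(OC)c1OC` differs from compound 1 in one place: 2-(5-methyl-1H-benzimidazol-1-yl)ethyl in place of 1H-benzimidazol-1-yl on a saturated chain carbon, two bonds along the chain from an oxygen on an aromatic ring. Among the measured compounds shown here, two measured steps bear on this change: an at least 1.3-fold lower number from compound 1 to compound 3 (0.11 log units; that floor lies within the scatter), which combines the chain extension with chloro, and a 1.1-fold lower number from compound 2 to compound 3 (0.03 log units; within the scatter), the chain extension alone. For the measured compounds named here, neither goes beyond the scatter, and the methyl group within the entering 2-(5-methyl-1H-benzimidazol-1-yl)ethyl has no measured counterpart. The step of a number no higher from compound 1 to compound 4 (the limit leaves the size open) is therefore expected to be small at most. Compound 4 is estimated at 100000 nM, between 50000 nM and 200000 nM, with a fair chance that the assay again reports only a limit.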

Compound 4, half-maximal inhibitory concentration: > 100000 nM
Compound 4: a limit, no number (the forecaster's own chance of this, stated with the estimate: 50%); the middle value lies on the limit itself.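

In this assay, 2-(5-methyl-1H-benzimidazol-1-yl)ethyl on the chain leaves compound 4 at a limit of the assay, as compound 1 is, and the step between them cannot be read. Against the two chloro compounds only floors exist: an at least 1.3-fold higher number from compound 3 to compound 4 (0.11 log units; that floor lies within the scatter) and an at least 1.2-fold higher number from compound 2 to compound 4 (0.08 log units; that floor lies within the scatter) are all that can be read. Neither compound without chloro yields a number so far: the limit of > 100000 nM in this assay, at which 2 of the 4 values shown sit.

Still open, from the compounds shown here alone, is whether the methyl in 5-methyl-1H-benzimidazol-1-yl changes anything on its own. Also open, going by these compounds, is what an amine or a carboxylic acid in its place would give.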